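The compounds below may be only part of what the source reports. "The series", "measured", "known", "first", "only" and "open" are said of these compounds alone.

The measured compounds:

Compound 1, `CCC1(Cc2ccccc2)OS(=O)(=O)C=C1OCc1ccc(Cl)cc1`: in an ADME assay on HEL cells (Homo sapiens) for cytotoxicity, with a stated time of 3 days (a higher number here means that more compound is tolerated, a lower number that less compound is tolerated), compound 1 gives >= 50000 nM, which is a limit of the assay rather than a number.

Compound 2, `CCC1(Cc2ccccc2)OS(=O)(=O)C=C1OCc1ccc(Cl)c(Cl)c1`: in this assay compound 2 gives >= 20000 nM, again a limit of the assay and not a number.

Compound 2 therefore stands at a limit, as the limit of >= 20000 nM in this assay, at which 1 of the 2 values shown sits, records, while the other value of the pair sits at the limit of >= 50000 nM in this assay, at which 1 of the 2 values shown sits. Within the data shown here, the single measured step, a step that the two limits leave unreadable from compound 1 to compound 2, cannot be read in size, because both of its ends are limits. Compound 3, `CCC1(Cc2ccccc2)OS(=O)(=O)C=C1OCC=C(C)C`, has not yet been measured. It differs from compound 2 by 2-methylprop-1-en-1-yl in place of 3,4-dichlorophenyl on a saturated chain carbon bound to an oxygen on an unsaturated carbon. Among the measured compounds shown here, no measured step bears on this change: the one step available, from compound 1 to compound 2, exchanged hydrogen for chloro on an aromatic carbon and gave no readable size. Nothing in the data points to a step beyond the scatter in either direction, so the step from compound 2 to compound 3 is expected to be about a step that the limit leaves unreadable from compound 2 to compound 3. Compound 3 is estimated at 30000 nM, within a range from 10000 nM to 100000 nM, and a further limit rather than a number is the likeliest outcome.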

Compound 3, minimum cytotoxic concentration: 400000 nM
Compound 3: the middle estimate sits 13-fold (1.12 log units) below what was measured, outside the stated range (above it).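

In this assay, the steps to compound 3 from compound 1 and from compound 2 cannot be read in size: the values of compound 1 and compound 2 are limits of the assay, not numbers. The compounds shown leave open how much swapping 4-chlorophenyl or 3,4-dichlorophenyl for 2-methylprop-1-en-1-yl shifts the tolerated concentration.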